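Butyl in Place of an Acyl Group on the Ring Nitrogen

The source may hold more compounds than are shown below. What is called first, only, known or untested is meant among the compounds shown, and "the series" means these compounds.

Of the compounds shown here, three sharing one core have been measured in an assay on isolated protein for binding affinity to histamine H2 receptor (Homo sapiens); on this read-out lower numbers stand for stronger inhibition and higher numbers for weaker inhibition. Compound 1 `CCCCCC(=O)c1ccc(OCCCN2CCNCC2)cc1` gives 14500 nM. Compound 2 `CCCCCC(=O)c1ccc(OCCCN2CCN(C(=O)N3CCOCC3)CC2)cc1` gives 17800 nM, and compound 3 `CCCCCC(=O)c1ccc(OCCCN2CCN(C(=O)CSCC)CC2)cc1` gives 22900 nM. Compound 3 carries the highest of the three numbers, yet the step of a 1.6-fold higher number from compound 1 to compound 3 (0.20 log units; within the scatter) and the step of a 1.3-fold higher number from compound 2 to compound 3 (0.11 log units; within the scatter) both remain inside the scatter, as does the step of a 1.2-fold higher number from compound 1 to compound 2 (0.09 log units; within the scatter).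

Compound 4 `CCCCCC(=O)c1ccc(OCCCN2CCN(CCCC)CC2)cc1` has not yet been measured in this assay. It differs from compound 3 by butyl in place of ((ethylsulfanyl)methyl)carbonyl on an amine nitrogen in a ring. Within the data shown here, every measured step altered the group on that same ring nitrogen, and every one of them stayed within the scatter; none of them, however, placed a plain alkyl chain there, so the data give no direct precedent. On that basis the expected step in this assay is a 1.5-fold lower number from compound 3 to compound 4 (0.18 log units; within the scatter), with no shift anticipated beyond the scatter. Compound 4 is accordingly estimated at 15000 nM, within a range from 5000 nM to 45000 nM.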

Compound 4, inhibition constant: 7590 nM
The estimate for compound 4 lay 2.0-fold (0.30 log units) above the measured number; the measured number falls inside the stated range.
By their numbers in this assay, from the lowest: compounds 4, 1, 2 and 3 (each within the scatter of the next, the first and the last beyond it).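

In this assay, among these compounds, the group on this ring nitrogen now makes a measurable difference: butyl gives the first steps beyond the scatter, a 3.0-fold lower number from compound 3 to compound 4 (0.48 log units; beyond the scatter) and a 2.3-fold lower number from compound 2 to compound 4 (0.37 log units; beyond the scatter), both modest and both replacing a group attached through a carbonyl. Against the unsubstituted nitrogen the same chain gives a 1.9-fold lower number from compound 1 to compound 4 (0.28 log units; within the scatter), so butyl separates compound 4 only from compound 2 and compound 3, not from compound 1. Nothing available explains this difference between butyl and the two carbonyl-linked groups.

The compounds shown leave open whether a shorter chain such as ethyl, a longer chain such as hexyl or a benzyl group on that nitrogen would lower the number further. They also leave open whether a simple acetyl group there would group with compound 2 and compound 3 or with compound 4.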